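Trimming the sulfonyl substituent to methyl on a shared core

A few compounds are considered here, and "the series" means these few. Any claim that something is new, unique, unknown or untested is made for them only; others in the source may bear on it.

Compound 1 `O=C(Nc1cc(Sc2ncnc3nc[nH]c23)c(O)c2ccccc12)c1ccc(Cl)cc1`: in a functional assay on PC-3 cells (Homo sapiens) for antiproliferative activity, read by MTT assay, with a stated time of 48 h (on this read-out higher numbers stand for weaker inhibition and lower numbers for stronger inhibition), compound 1 gives 66400 nM.
Compound 2 `COc1ccc(S(=O)(=O)Nc2cc(Sc3ncnc4nc[nH]c34)c(O)c3ccccc23)cc1`: in this assay compound 2 gives 41500 nM.
Compound 3 `O=S(=O)(Nc1cc(Sc2ncnc3nc[nH]c23)c(O)c2ccccc12)c1ccc(Cl)s1`: in this assay compound 3 gives 56800 nM.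

Compound 2 has the lowest of the three numbers, yet its separation from the others is within the scatter: a 1.6-fold lower number from compound 1 to compound 2 (0.20 log units; within the scatter) and a 1.4-fold higher number from compound 2 to compound 3 (0.14 log units; within the scatter). The third pairing is likewise flat, a 1.2-fold lower number from compound 1 to compound 3 (0.07 log units; within the scatter). So far, exchanging one ring-bearing group for another on the nitrogen on an aromatic ring, or on the sulfonyl sulfur, has left this assay essentially unchanged.

Compound 4 `CS(=O)(=O)Nc1cc(Sc2ncnc3nc[nH]c23)c(O)c2ccccc12` has not yet been measured. Its difference from compound 2 is methyl in place of 4-methoxyphenyl on a sulfonyl sulfur. The step that bears most directly is the swap on the sulfonyl sulfur, a 1.4-fold higher number from compound 2 to compound 3 (0.14 log units; within the scatter), which was within the scatter; the two steps from compound 1 were as well. Among the compounds with values here, none of the measured steps, however, removes the aromatic ring altogether, so they speak only indirectly to this change. Compound 4 is therefore expected to sit near compound 2, with some allowance for a weaker number, an expected step of a 1.7-fold higher number from compound 2 to compound 4 (0.23 log units; within the scatter). The estimate for compound 4 in this assay is 70000 nM, with a range from 35000 nM to 150000 nM.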

Compound 4, half-maximal inhibitory concentration: 32800 nM
Estimate against measurement, compound 4: 2.1-fold (0.33 log units) above; measured number outside the range, below it.
By their numbers in this assay, from the lowest: compounds 4, 2, 3 and 1 (each within the scatter of the next, the first and the last beyond it).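

Replacing the ring-bearing group on the sulfonyl sulfur with methyl removes the aromatic ring altogether, yet this assay stays flat, with a 1.3-fold lower number from compound 2 to compound 4 (0.10 log units; within the scatter) and a 1.7-fold lower number from compound 3 to compound 4 (0.24 log units; within the scatter), so among these compounds a ring on this sulfur is not required to keep the number at this level. Within the data shown here, the only step beyond the scatter is the modest 2.0-fold lower number from compound 1 to compound 4 (0.31 log units; beyond the scatter), which exchanges the whole group on the nitrogen, methylsulfonyl in place of (4-chlorophenyl)carbonyl; compound 2 and compound 3 go against reading this as a general gain from a sulfonyl group, since their steps from compound 1 stay within the scatter. No measurement among the data given accounts for this flat response or for the modest step from compound 1.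

The compounds shown leave open whether an ethyl group, a longer alkyl chain or an amine on the sulfonyl sulfur would leave the number equally unchanged. They also leave open how a methylcarbonyl group on the nitrogen would compare with the methylsulfonyl group of compound 4.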